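Phenyl for benzyl on the carbamate nitrogen: one measured precedent

The compounds below may be only part of what the source reports. "The series", "measured", "known", "first", "only" and "open" are said of these compounds alone.

Measured compounds:
compound 1, `O=C(Nc1ccccc1)Oc1ccccc1C(=O)Nc1ccccc1`: in an ADME assay on HepG2 cells (Homo sapiens), read by MTT assay, with a stated time of 72 h, in the presence of a further agent that is not named here (on this read-out lower numbers stand for stronger inhibition and higher numbers for weaker inhibition), compound 1 gives 26800 nM
compound 2, `O=C(NCc1ccccc1)Oc1ccc(Cl)cc1C(=O)Nc1ccc(C(F)(F)F)cc1`: in this assay compound 2 gives 3000 nM
compound 3, `O=C(NCc1ccccc1)Oc1ccccc1C(=O)Nc1ccccc1`: in this assay compound 3 gives 54300 nM

Compound 2 shows the lowest number of the three. The difference between its core and that of compound 3 is not broken down here.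

Compound 4, `O=C(Nc1ccccc1)Oc1ccc(Cl)cc1C(=O)Nc1ccc(C(F)(F)F)cc1`, is not yet measured. It differs from compound 2 by phenyl in place of benzyl on an amide-type nitrogen. The same change, at the same place, has been measured once, from compound 3 to compound 1: phenyl in place of benzyl on an amide-type nitrogen, giving a 2.0-fold lower number from compound 3 to compound 1 (0.31 log units; beyond the scatter).

The step expected from this change is a 2.0-fold lower number from compound 2 to compound 4 (0.30 log units; within the scatter). For the measured compounds named here, this rests on a 2.0-fold lower number from compound 3 to compound 1 (0.31 log units; beyond the scatter) as the single measured instance, with no second pair to show whether the size carries over to the core of compound 2. Compound 4 is accordingly estimated at 1500 nM, with a likely range from 700 nM to 3500 nM.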

Compound 4, half-maximal inhibitory concentration: 2450 nM
Beside the measured number, compound 4's estimate is 1.6-fold (0.21 log units) below it; the measured number falls inside the stated range.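

In this assay phenyl in place of benzyl on the amide-type nitrogen gives a 1.2-fold lower number from compound 2 to compound 4 (0.09 log units; within the scatter) on the core of compound 2, and the two measured steps for this change do not differ beyond the scatter: the same change on two cores in this assay, a 2.0-fold lower number (0.31 log units; beyond the scatter) from compound 3 to compound 1 and a 1.2-fold lower number (0.09 log units; within the scatter) from compound 2 to compound 4, 1.7-fold (0.22 log units) apart, within the scatter of two such steps

On these two cores, then, the change carries over as a small step with no sign of dependence on the core. Two pairs remain a narrow base, and they do not show that the step holds on any other core in the series.

Open, going by these compounds, are groups other than benzyl and phenyl on this nitrogen, such as a longer chain like phenethyl or a plain methyl. Also open, on these data alone, are the separate contributions of the chlorine and the trifluoromethyl group in the core of compound 2.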